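One amide substituent exchanged on compound 2

The compounds below may be only part of what the source reports. "The series", "measured", "known", "first", "only" and "open" are said of these compounds alone.

Compound 1 `Cn1ccc2ccc(-c3cc(Nc4ccccc4S(=O)(=O)N4CCOCC4)cc4nccnc34)cc21` gives 0.367 h
Compound 2 `Cn1ccc2ccc(-c3cc(Nc4cnccc4C(=O)NCc4cncnc4)cc4nccnc34)cc21` gives 0.4 h

In an ADME assay on microsomes from liver (Mus musculus, strain CD-1) for metabolic stability, read by LC-MS, tested at 2 uM (a lower number here means that the compound disappears faster, a higher number that the compound lasts longer), compound 2, at 0.4 h, stands within the scatter of compound 1. Compound 3 `CN1CCC(NC(=O)c2ccncc2Nc2cc(-c3ccc4ccn(C)c4c3)c3nccnc3c2)CC1` departs from compound 2 on an amide-type nitrogen, where 1-methylpiperidin-4-yl takes the place of (pyrimidin-5-yl)methyl: 1-methylpiperidin-4-yl in place of (pyrimidin-5-yl)methyl on an amide-type nitrogen. Among the compounds with values here, no measured pair shows what this exchange does, so in this assay no step beyond the scatter is expected, in either direction. The expected step is a 1.1-fold lower number from compound 2 to compound 3 (0.06 log units; within the scatter). The half-life estimated for compound 3 is 0.35 h, with an expected range of 0.15 h to 0.8 h.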

Compound 3, half-life: > 1 h
Compound 3 was reported as a limit; the forecaster's own chance of this, stated with the estimate: 3%; middle value at least 2.8-fold (0.45 log units) away from the limit.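

On the amide-type nitrogen, the substituent proves to matter in this assay: 1-methylpiperidin-4-yl in place of (pyrimidin-5-yl)methyl gives an at least 2.5-fold higher number from compound 2 to compound 3 (0.39 log units; beyond the scatter). Compound 3 stands at > 1 h, which is a limit of the assay and not a number. The full size of the step therefore remains unfixed: the limit of > 1 h in this assay, at which 1 of the 3 values shown sits.

The compounds shown do not tell whether the step belongs to the ring as a whole or to its methyl group. Nor do they show whether piperidin-4-yl without the methyl, or an open-chain amine such as 2-(dimethylamino)ethyl, would behave alike on this nitrogen.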